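Ethynyl in place of vinyl on the shared core

The source may hold more compounds than are shown below. What is called first, only, known or untested is meant among the compounds shown, and "the series" means these compounds.

For the measured compounds named here, compound 3 `C=Cc1cn([C@@H]2C=C(CO)[C@@H](O)[C@H]2O)c2ncnc(C)c12` is the one member of the series that yields a number in an ADME assay on Huh-7 cells (Homo sapiens) for cytotoxicity; a lower number here means that less compound is tolerated, a higher number that more compound is tolerated: compound 3 gives 52800 nM. Compound 1 `Cc1ncnc2c1c(F)cn2[C@@H]1C=C(CO)[C@@H](O)[C@H]1O` reaches only the limit of the assay, > 100000 nM. Compound 2 `Cc1ncnc2c1c(I)cn2[C@@H]1C=C(CO)[C@@H](O)[C@H]1O` likewise reaches only the limit, > 100000 nM. That mark is the limit of > 100000 nM in this assay, at which 2 of the 3 values shown sit. Going by the values given here, the steps of an at least 1.8-fold lower number from compound 1 to compound 3 (0.27 log units; that floor lies within the scatter) and an at least 1.8-fold lower number from compound 2 to compound 3 (0.27 log units; that floor lies within the scatter) are the only measured ones touching compound 3, and each is a floor within the scatter. Compound 4 `C#Cc1cn([C@@H]2C=C(CO)[C@@H](O)[C@H]2O)c2ncnc(C)c12` differs from compound 3 by ethynyl in place of vinyl on an aromatic carbon. Among the compounds with values here, no measured step covers this change, and the neighbouring steps read nothing beyond the scatter. The expected step of a 1.1-fold higher number from compound 3 to compound 4 (0.06 log units; within the scatter) is therefore close to none. For compound 4 the estimate is 60000 nM, with a range from 25000 nM to 150000 nM.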

Compound 4, half-maximal cytotoxic concentration: > 100000 nM
Compound 4 was reported as a limit (the forecaster's own chance of this, stated with the estimate: 35%); at least 1.6-fold (0.22 log units) between middle value and limit.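

Compound 4 is a limit in this assay, and ethynyl on this aromatic carbon adds to the values gathered at one mark: the limit of > 100000 nM in this assay, at which 3 of the 4 values shown sit.

Ethynyl in place of vinyl gives an at least 1.8-fold higher number from compound 3 to compound 4 (0.27 log units; that floor lies within the scatter), so compound 3 remains the only member with a number, set apart from the others only by floors within the scatter. The steps from compound 1 and from compound 2 to compound 4 cannot be read, as both ends of each are limits.

On these data alone, whether any group at this position gives a step beyond the scatter stays open. An amine, a carboxylic acid or a longer chain on this aromatic carbon would bear on that.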